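Swapping a Bromine for Two Fluorines on a Pendant Ring

The source may hold more compounds than are shown below. What is called first, only, known or untested is meant among the compounds shown, and "the series" means these compounds.

Compound 1 `CC(=O)Nc1cccc(C2CCN(CCn3c(-c4ccccc4)nc4ccccc43)CC2)c1` gives 10000 nM in an assay for displacement of a labelled ligand from melanin-concentrating hormone receptor 1 (Homo sapiens), read by fluorescence; on this read-out higher numbers stand for weaker inhibition and lower numbers for stronger inhibition.
Compound 2 `CC(=O)Nc1cccc(C2CCN(CCCn3c(-c4ccc(Br)cc4)nc4ccccc43)CC2)c1` gives 5 nM in this assay.

Of the two numbers shown, compound 2 stands lowest, which on this read-out means the stronger inhibition; compound 1 stands far higher, and the gap between them lies well beyond the scatter. Compound 1 and compound 2 differ from each other in more than one place, so no single step can be drawn between them, and only their two values are shown.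

Compound 3 `CC(=O)Nc1cccc(C2CCN(CCCn3c(-c4ccc(F)c(F)c4)nc4ccccc43)CC2)c1` has not yet been measured. It differs from compound 2 in one place: 3,4-difluorophenyl in place of 4-bromophenyl on an aromatic carbon. Among the measured compounds shown here, no measured pair here shows what such an exchange does, so the expectation rests on compound 2 alone. The step from compound 2 to compound 3 is expected to be small and, if anything, towards a higher number, as a 3.0-fold higher number from compound 2 to compound 3 (0.48 log units; beyond the scatter). Compound 3 is therefore estimated to give about 15 nM in this assay, somewhere between 3 nM and 80 nM.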

Compound 3, half-maximal inhibitory concentration: 4 nM
Beside the measured number, compound 3's estimate is 3.8-fold (0.57 log units) above it, and the stated range covers the measured number.
By their numbers in this assay, from the lowest: compounds 3 and 2 (each within the scatter of the next); then compound 1.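

In this assay, replacing 4-bromophenyl with 3,4-difluorophenyl gives a 1.3-fold lower number from compound 2 to compound 3 (0.10 log units; within the scatter) and so leaves the two compounds indistinguishable on this read-out. Among the compounds shown here, this is the first comparison here that changes only one place, and it shows that this aromatic carbon, between two ring nitrogen atoms, can carry either substituted ring with no measurable difference, even though a single bromine gives way to two fluorines and the group grows from 7 heavy atoms to 8. No measurement is available to explain why the two values match so closely.

Compound 1 carries an unsubstituted phenyl at this position but differs from compound 2 in more than one place, so the separate contributions of the halogens and the chain cannot be read from it. As far as these compounds go, it also remains open whether a pendant ring bearing a methoxy group or a nitrile would stay in the same range in this assay or mark the point where this position stops accepting such exchanges.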